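The source may hold more compounds than are shown below. What is called first, only, known or untested is meant among the compounds shown, and "the series" means these compounds.

In a functional assay on Raji cells (Homo sapiens) for cytotoxicity, with a stated time of 72 h (a higher number here means that more compound is needed for the effect, a lower number that less compound is needed), compound 1 `C=C[C@@](C)(/C=C/c1ccc(O)c(/C=C/C(=O)OCC)c1)CCC=C(C)C` gives > 26000 nM, which is a limit and not a number. Compound 2 `C=C[C@@](C)(/C=C/c1ccc(O)c(/C=C(\C)C(=O)OCC)c1)CCC=C(C)C` gives > 26000 nM, which is also a limit. Going by the values given here, compound 2 therefore has no exact position on the scale, and the only further value shown is a limit too. The next change gives compound 3 `C=C[C@@](C)(/C=C/c1ccc(O)c(/C=C/c2ccc(Cl)cc2)c1)CCC=C(C)C`, with 2-(4-chlorophenyl)ethenyl in place of 2-(ethoxycarbonyl)prop-1-en-1-yl on an aromatic carbon. Among the compounds with values here, the one measured step, a step that the two limits leave unreadable from compound 1 to compound 2, changes the group on an aromatic carbon, but it has no readable size. Because of the limit of > 26000 nM in this assay, at which 2 of the 2 values shown sit, no measured size can be carried over to this new change. In this assay only a modest shift towards less compound needed is expected, an estimated at least 1.3-fold lower number from compound 2 to compound 3 (0.11 log units; that floor lies within the scatter). For compound 3 the expected value is 20000 nM, with an estimated range of 6000 nM to 45000 nM.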

Compound 3, half-maximal effective concentration: > 26000 nM
Compound 3 ended at the assay's limit (the forecaster's own chance of this, stated with the estimate: 50%); middle value at least 1.3-fold (0.11 log units) away from the limit.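

The steps between compound 1, compound 2 and compound 3 cannot be read, because all three compounds stop at the same limit: the limit of > 26000 nM in this assay, at which 3 of the 3 values shown sit. The compounds shown leave open how much of each is needed for the effect in this assay and whether exchanging these groups shifts that amount at all.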